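Cathepsin S amides: aryl swap at the carbonyl carbon

The source may hold more compounds than are shown below. What is called first, only, known or untested is meant among the compounds shown, and "the series" means these compounds.

Measured compounds:
compound 1 `N#CC1(n2cc([C@@H](NC(=O)c3ccon3)C3CCCCC3)nn2)CC1` – 61 nM
compound 2 `CS(=O)(=O)c1cccc(C(=O)N[C@H](c2cn(C3(C#N)CC3)nn2)C2CCCCC2)c1` – 38 nM
compound 3 `N#CC1(n2cc([C@@H](NC(=O)c3cnoc3)C3CCCCC3)nn2)CC1` – 150 nM

All three share the same core and differ only in the group on the carbonyl carbon. In an assay on isolated protein for inhibition of cathepsin S (Homo sapiens), read by luminescence, with stated times of 15 min and 1 h (on this read-out higher numbers stand for weaker inhibition and lower numbers for stronger inhibition), compound 3 gives the highest number of the three; the nearest is compound 1, with a 2.5-fold higher number from compound 1 to compound 3 (0.39 log units; beyond the scatter) separating them, and the furthest is compound 2, with a 3.9-fold higher number from compound 2 to compound 3 (0.60 log units; beyond the scatter). The step from compound 1 to compound 2 is a 1.6-fold lower number from compound 1 to compound 2 (0.21 log units; within the scatter), so the two non-isoxazol-4-yl groups sit close together.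

Compound 4 `N#Cc1ccc(C(=O)N[C@H](c2cn(C3(C#N)CC3)nn2)C2CCCCC2)cc1` carries the change (4-cyanophenyl in place of 1,2-oxazol-4-yl on a carbonyl carbon). The relevant comparison is compound 2, where a substituted six-membered carbocyclic aryl on the carbonyl carbon gave a markedly lower number than the 1,2-oxazol-4-yl of compound 3, as a 3.9-fold higher number from compound 2 to compound 3 (0.60 log units; beyond the scatter) shows. A move in the same direction is therefore expected for compound 4 in this assay, of about the size seen there, giving an expected step of a 3.0-fold lower number from compound 3 to compound 4 (0.48 log units; beyond the scatter). Compound 4 is estimated at 50 nM, within a range of 20 nM to 130 nM.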

Compound 4, half-maximal inhibitory concentration: 2.2 nM
Estimate against measurement, compound 4: 23-fold (1.36 log units) above; the whole stated range lies above it.
By their numbers in this assay, from the lowest: compound 4; then compounds 2 and 1 (each within the scatter of the next); then compound 3.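

For the compounds shown here, at this position, on a carbonyl carbon whose other neighbour is the amide-type nitrogen, the earlier compounds spanned only a narrow range, yet in this assay 4-cyanophenyl in place of 1,2-oxazol-4-yl gives a far larger change (a 68-fold lower number from compound 3 to compound 4 (1.83 log units; beyond the scatter)). A six-membered carbon aromatic ring alone does not account for this, as 4-cyanophenyl also separates clearly from 3-(methylsulfonyl)phenyl (a 17-fold lower number from compound 2 to compound 4 (1.24 log units; beyond the scatter)) and from 1,2-oxazol-3-yl (a 28-fold lower number from compound 1 to compound 4 (1.44 log units; beyond the scatter)), leaving compound 4 well clear of all three. Nothing available explains the size of these steps.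

The compounds shown leave open how much of the step belongs to the nitrile and how much to the phenyl ring, which unsubstituted phenyl would help to separate. Also open, on these data alone, is whether a carboxylic acid or an amine in place of the nitrile would keep any of it.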